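The source may report more compounds than this note shows. Statements on the series, on what has been measured and on what is new or still open speak of the compounds shown alone.

Measured so far:
compound 1 (`CCCCCCNc1ccc(C(=O)O)cc1S(=O)(=O)N(C)C`) gives 243000 nM
compound 2 (`CN(C)S(=O)(=O)c1cc(C(=O)O)c(Cl)cc1NCCCCCCCC(F)(F)F`) gives 241000 nM

Both numbers come from a physicochemical assay for solubility, in phosphate buffer, measured as kinetic solubility, at pH 7.4, tested at 250 uM (on this read-out higher numbers stand for higher solubility and lower numbers for lower solubility), and lie within the scatter of each other, so compound 2 stands level with compound 1. These two compounds differ in more than one place, so the data hold no direct guide to the effect of a single change. Compound 3 (`COc1cc(NCCCCCCCC(F)(F)F)c(S(=O)(=O)N(C)C)cc1C(=O)O`) carries methoxy in place of chloro on an aromatic carbon, ortho to a carboxy group (methoxy in place of chloro on an aromatic carbon). With compound 2 (241000 nM) as the starting point and nothing measured for this swap, no shift beyond the scatter is expected in this assay, and the read-out cannot climb far past the concentration tested. The expected change is small (a 1.0-fold lower number from compound 2 to compound 3 (0.01 log units; within the scatter)). Compound 3 is estimated at 235000 nM (expected range 150000 nM to 260000 nM).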

Compound 3, solubility: 188000 nM
Compound 3: middle estimate off by 1.3-fold (0.10 log units), on the high side, within the range that was stated.
By their numbers in this assay, from the lowest: compounds 3, 2 and 1 (each within the scatter of the next).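

In this assay, the swap of chloro for methoxy on this aromatic carbon, ortho to a carboxy group and para to a dimethylsulfamoyl group, gives a 1.3-fold lower number from compound 2 to compound 3 (0.11 log units; within the scatter). Among the compounds shown here, this is the first step that changes a single place, and it shows that this position can carry methoxy, with the hydrogen-bond acceptor it brings, without a shift beyond the usual scatter. With both numbers close to the concentration tested, this read-out may have little room to show a larger difference, and no measurement here offers an explanation for the step.

From the compounds shown here alone, whether a nitrile or an amine at this position would also stay level with chloro and methoxy remains open. So does whether methoxy would behave the same way on the core of compound 1.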